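The source may report more compounds than this note shows. Statements on the series, on what has been measured and on what is new or still open speak of the compounds shown alone.

In an ADME assay on L1210/0 cells (Mus musculus) for cytotoxicity, with a stated time of 48 h (a lower number here means a stronger inhibitor, a higher number a weaker inhibitor), compound 1 `CC1(C)[C@@H](CO)CC[C@@]1(C)Cn1ccc(=O)[nH]c1=O` gives > 200000 nM, which is a limit of the assay and not a number. Compound 2 `Nc1nc2c(nc(N)n2COCCO)c(=O)[nH]1` reads > 200000 nM, likewise only a limit. Compound 3 `Nc1nc2c(nc(O)n2COCCO)c(=O)[nH]1` differs from compound 2 by hydroxy in place of amino on an aromatic carbon, with hydroxy in place of amino on an aromatic carbon. Among the measured compounds shown here, no measured step between compounds is available as a guide. With compound 2 reading > 200000 nM, no step beyond the scatter is expected in this assay, and a further limit is the likely report. The expected value for compound 3 is 200000 nM, with an estimated range from 100000 nM to 400000 nM.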

Compound 3, half-maximal inhibitory concentration: > 200000 nM
Compound 3: a limit, no number; the forecaster's own chance of this, stated with the estimate: 85%; the middle value lies on the limit itself.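

No step can be read between compound 2 and compound 3, as both give only a limit: the limit of > 200000 nM in this assay, at which 3 of the 3 values shown sit.

The compounds shown leave open what number any of them would give, and so whether hydroxy in place of amino changes anything.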